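This account rests on a few compounds, and the source may have more. Where it says the series, first, only, none or still open, it means among the compounds named here.

The measured compounds and their values in a functional assay on the whole organism for antagonist activity, with Mus musculus as the target; on this read-out higher numbers stand for an effect only at larger amounts of compound and lower numbers for an effect already at smaller amounts:

Compound 1 `COc1cc(N)c(Cl)cc1NC(=O)C1CCN(C2CCCC2)CC1` gives > 10 mg/kg, which is a limit of the assay.
Compound 2 `COc1cc(N)c(Cl)cc1NC(=O)C1CCN(Cc2cccc(C)c2)CC1` gives 2.4 mg/kg.
Compound 3 `CCCN1CCC(C(=O)Nc2cc(Cl)c(N)cc2OC)CC1` gives > 10 mg/kg, which is a limit of the assay.

Compound 3 thus stands at the limit of > 10 mg/kg in this assay, at which 2 of the 3 values shown sit, and no number was read for it. Only compound 2 yields a number among the three.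

The unmeasured compound 4 `CCCCN1CCC(C(=O)Nc2cc(Cl)c(N)cc2OC)CC1` differs from compound 3 by methyl in place of hydrogen on a saturated chain carbon, three bonds along the chain from an amine nitrogen in a ring. Among the compounds with values here, two measured steps bear on changes at the amine nitrogen in the ring. The step that the two limits leave unreadable from compound 1 to compound 3 runs between two limits, so its size cannot be read. The step of an at least 4.1-fold higher number from compound 2 to compound 3 (0.61 log units; beyond the scatter) shows that removing the 3-methylphenyl sends the value to the limit, and the step of an at least 4.1-fold lower number from compound 1 to compound 2 (0.61 log units; beyond the scatter) shows the same in the opposite direction. The change from propyl to butyl is far smaller than either of those replacements, and nothing measured here separates one short chain from another.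

Compound 4 is therefore expected to remain near the limit. The estimate for compound 4 in this assay is 10 mg/kg, within a range from 3 mg/kg to 30 mg/kg. The step of a number no higher from compound 3 to compound 4 (the limit leaves the size open) is expected to stay within the scatter.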

Compound 4, dose for half-maximal effect: > 10 mg/kg
Compound 4 gave a limit, no number; the forecaster's own chance of this, stated with the estimate: 65%; the middle value lies on the limit itself.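

In this assay compound 4 gives > 10 mg/kg, which is a limit of the assay and not a number, so methyl in place of hydrogen on a saturated chain carbon, three bonds along the chain from an amine nitrogen in a ring, brings no readable value and the butyl compound joins the others at that limit: the limit of > 10 mg/kg in this assay, at which 3 of the 4 values shown sit.

Within the data shown here, the earlier compounds set only propyl and cyclopentyl against 3-methylbenzyl, and butyl now widens that contrast with an at least 4.1-fold higher number from compound 2 to compound 4 (0.61 log units; beyond the scatter), leaving 3-methylbenzyl as the only group on this nitrogen with a measured number among the four compounds. The steps among compound 1, compound 3 and compound 4 run between limits and cannot be read, so any difference between propyl and butyl stays hidden.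

The compounds shown leave open whether a longer chain such as hexyl would bring a number into reach, or whether this needs an aromatic ring on the chain, as a plain benzyl or a phenethyl group could show. They also leave open what the methyl of the 3-methylbenzyl group contributes, since no benzyl group without it stands beside compound 2.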